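The compounds below may be only part of what the source reports. "The series", "measured", "known", "first", "only" and "open" are said of these compounds alone.

Measured compounds:
- compound 1, `O=S(=O)(c1cc(Cl)cc(Cl)c1)c1cnc2cc(F)ccc2c1-c1ccccc1F`: 0.93 mL/min
- compound 2, `COc1ccc(S(=O)(=O)c2cnc3cc(F)ccc3c2-c2ccc(F)cc2)cc1Cl`: 1.29 mL/min

In an ADME assay on microsomes from liver (Homo sapiens) for metabolic stability, tested at 2.5 uM (a higher number here means faster removal of the compound, a lower number slower removal), compound 1 gives 0.93 mL/min, and compound 2 gives 1.29 mL/min; the two numbers sit within the scatter of each other, so compound 1 holds the smaller figure only nominally.

Compound 3, `O=S(=O)(c1cc(Cl)cc(Cl)c1)c1cnc2cc(F)ccc2c1-c1ccc(Cl)cc1`, is not yet measured in this assay. It differs from compound 1 as follows: 4-chlorophenyl in place of 2-fluorophenyl on an aromatic carbon. Within the data shown here, no step between measured compounds covers a change of this kind, so the expectation rests on compound 1 alone.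

The step from compound 1 to compound 3 in this assay is expected to be small, a 1.3-fold higher number from compound 1 to compound 3 (0.11 log units; within the scatter), not beyond the scatter. Compound 3 is accordingly estimated at 1.2 mL/min, within 0.6 mL/min to 2.4 mL/min.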

Compound 3, intrinsic clearance in a liver preparation (reported as CLH), per the amount of preparation that the assay uses: 0.13 mL/min
Compound 3: middle estimate off by 9.2-fold (0.97 log units), on the high side, outside the stated range (below it).
By their numbers in this assay, from the lowest: compound 3; then compounds 1 and 2 (each within the scatter of the next).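

In this assay the position opposite the ring nitrogen proves sensitive to the aryl group: there is a 7.2-fold lower number from compound 1 to compound 3 (0.85 log units; beyond the scatter) with 4-chlorophenyl in place of 2-fluorophenyl. Both groups have the same heavy-atom count and a single carbon-only aromatic ring, so these shared counts do not settle the read-out here. No measured evidence accounts for the step. From the compounds shown here alone, the change moves the substituent and exchanges fluorine for chlorine together, so the contribution of each remains open. Going by these compounds, how an amine or a carboxylic acid would behave at this position also remains open.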